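The source may hold more compounds than are shown below. What is called first, only, known or untested is meant among the compounds shown, and "the series" means these compounds.

Compound 1 `Cc1ccc2nc(Nc3nc(Nc4ccc(S(N)(=O)=O)cc4)ncc3F)sc2c1` and compound 2 `NS(=O)(=O)c1ccc(Nc2ncc(F)c(Nc3nc4ccc(Cl)cc4s3)n2)cc1` are built on one core, while compound 3 `Cc1ccc2nc(Nc3ccnc(Nc4ccc(S(C)(=O)=O)cc4)n3)sc2c1` and compound 4 `CS(=O)(=O)c1ccc(Nc2nccc(Nc3nc4ccc(Cl)cc4s3)n2)cc1` are built on another; the difference between the two cores is not broken down here.

In a functional assay on PC-3 cells (Homo sapiens) for antiproliferative activity, read by MTT assay, with a stated time of 48 h (on this read-out higher numbers stand for weaker inhibition and lower numbers for stronger inhibition), compound 1 gives 4960 nM. Compound 2 gives 1430 nM in this assay. Going by the values given here, the single change between them is chloro in place of methyl on an aromatic carbon, and it produced a 3.5-fold lower number from compound 1 to compound 2 (0.54 log units; beyond the scatter).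

For compound 3 this assay reports only a limit, > 50000 nM, and not a number. That limit is the one described as the limit of > 50000 nM in this assay, at which 1 of the 3 values shown sits.

Among the compounds with values here, compound 4 differs from compound 3 by chloro in place of methyl on an aromatic carbon, which is the same change, at the same place, as the one that separates compound 1 from compound 2. Within the data shown here, the only measured instance of this change is the step from compound 1 to compound 2, so the expectation for compound 4 rests on a 3.5-fold lower number from compound 1 to compound 2 (0.54 log units; beyond the scatter) alone. Since compound 3 has only a limit rather than a number, the starting point for compound 4 is itself uncertain, and a value close to or at the limit remains quite possible.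

Compound 4 is therefore expected to give about 30000 nM in this assay, with an estimated range from 8000 nM to 100000 nM. Relative to compound 3 this estimate means an expected step of an at least 1.6-fold lower number from compound 3 to compound 4 (0.22 log units; that floor lies within the scatter).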

Compound 4, half-maximal inhibitory concentration: > 50000 nM
Compound 4: no number, only a limit; the forecaster's own chance of this, stated with the estimate: 55%; middle value at least 1.6-fold (0.22 log units) from the limit.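

In this assay compound 4 gives > 50000 nM, which is a limit and not a number. Compound 3 also has only a limit, so no step can be read between compound 3 and compound 4: the limit of > 50000 nM in this assay, at which 2 of the 4 values shown sit. The compounds shown leave open whether chloro in place of methyl on an aromatic carbon changes activity at all on the core of compound 3, as it does on the core of compound 1.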